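The compounds below may be only part of what the source reports. "The series", "measured", "known", "first", "only" and "open" are said of these compounds alone.

Measured values for the series:
- compound 1, `CN1CCN(C[C@H]2CN(c3ccc(-n4cc(-c5ccccn5)cn4)c(F)c3)C(=O)O2)CC1`: 2.2
- compound 2, `O=C1O[C@@H](CN2CCCCC2)CN1c1ccc(-n2cc(-c3ccccn3)cn2)c(F)c1`: 3.1
- compound 3, `COC(=O)CC1CCN(C[C@H]2CN(c3ccc(-n4cc(-c5ccccn5)cn4)c(F)c3)C(=O)O2)CC1`: 1.78

In a physicochemical assay for lipophilicity, read by HPLC, measured as octanol-water partition (on this read-out higher numbers stand for higher lipophilicity and lower numbers for lower lipophilicity), compound 1 sits second highest of the three. Its nearest neighbour is compound 3, reached by a number 0.42 log units lower from compound 1 to compound 3 (beyond the scatter); the furthest is compound 2, reached by a number 0.90 log units higher from compound 1 to compound 2 (beyond the scatter). Between the two piperidines the step is a number 1.32 log units lower from compound 2 to compound 3 (beyond the scatter).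

The next compound, compound 4, has the structure `COC(=O)NC[C@H]1CN(c2ccc(-n3cc(-c4ccccn4)cn3)c(F)c2)C(=O)O1`. It differs from compound 1 by (methoxycarbonyl)amino in place of 4-methylpiperazin-1-yl on a saturated chain carbon bound to a saturated ring carbon.

Within the data shown here, no measured step covers this change directly. The steps at hand show two things: swapping one saturated ring for another at the same place moves this assay by a modest amount, and hanging a (methoxycarbonyl)methyl group on a ring carbon lowers it by a large one. Here the ring is removed altogether and a smaller, ring-free group carrying one hydrogen-bond donor enters. The closest guide is the lowering seen on going from compound 2 to compound 3 when an ester-bearing chain is added, though neither that step nor any other reports a carbamate.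

For compound 4 a modest fall in this assay is therefore expected, a number 0.25 log units lower from compound 1 to compound 4 (within the scatter), giving an estimated value of 1.95 with a range from 1.45 to 2.5.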

Compound 4, partition coefficient: 2.03
For compound 4 the middle estimate is 0.08 log units below the measured one, within the range that was stated.
By their numbers in this assay, from the lowest: compounds 3, 4 and 1 (each within the scatter of the next, the first and the last beyond it); then compound 2.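

In this assay, on a saturated chain carbon bound to a saturated ring carbon, the ring of 4-methylpiperazin-1-yl can give way to the ring-free (methoxycarbonyl)amino with only a number 0.17 log units lower from compound 1 to compound 4 (within the scatter), so a ring at this place is not needed to keep the read-out in the range of compound 1. Set against the other two groups, (methoxycarbonyl)amino gives a number 0.25 log units higher from compound 3 to compound 4 (within the scatter) but also a number 1.07 log units lower from compound 2 to compound 4 (beyond the scatter), which leaves compound 2 apart from the other three, while compound 4 falls within the scatter of both compound 1 and compound 3, even though those two lie beyond the scatter of each other. Nothing available here bears on the reason for these readings.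

Still open, as far as these compounds go, is whether the hydrogen-bond donor entering with (methoxycarbonyl)amino has any part in the reading, a question that an acetamide or a methyl group on the carbamate nitrogen would address. Also open, from the compounds shown here alone, is how a primary amine, a carboxylic acid or a longer chain ending in the same carbamate would read at this place.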